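The source may hold more compounds than are shown below. What is called first, only, known or untested is meant among the compounds shown, and "the series" means these compounds.

Compound 1 `CC(C)(C)c1ccc(NC(=O)c2ccc(-c3ncccc3NS(C)(=O)=O)cc2)cc1`: in a functional assay for antagonist activity at transient receptor potential cation channel subfamily V member 1 (Rattus norvegicus) (on this read-out lower numbers stand for stronger inhibition and higher numbers for weaker inhibition), compound 1 gives 35 nM.
Compound 2 `CC(C)(C)c1ccc(NC(=O)c2ccc(-c3ncccc3N(S(C)(=O)=O)S(C)(=O)=O)cc2)cc1`: in this assay compound 2 gives 0.4 nM.

For the measured compounds named here, compound 2 stands at the lowest number of the two, with compound 1 as its only neighbour. Going by the values given here, the single measured step, an 88-fold lower number from compound 1 to compound 2 (1.94 log units; beyond the scatter), shows how strongly this one position shapes the read-out. Compound 3 `Cc1nnc(-c2cccnc2-c2ccc(C(=O)Nc3ccc(C(C)(C)C)cc3)cc2)o1` changes the same position: 5-methyl-1,3,4-oxadiazol-2-yl in place of bis(methylsulfonyl)amino on an aromatic carbon. Among the compounds with values here, no measured step covers a group of this kind, so only the size of the known step hints at what moving away from the bis(methylsulfonyl)amino group costs. Compound 3 is therefore expected to give a higher number, a 50-fold higher number from compound 2 to compound 3 (1.70 log units; beyond the scatter), estimated at 20 nM within 2 nM to 200 nM.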

Compound 3, half-maximal inhibitory concentration: 34 nM
For compound 3 the middle estimate is 1.7-fold (0.23 log units) below the measured one; the range from low to high includes it.
By their numbers in this assay, from the lowest: compound 2; then compounds 3 and 1 (each within the scatter of the next).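

In this assay the oxadiazole does not keep the low number of the bis(methylsulfonyl)amino group, with an 85-fold higher number from compound 2 to compound 3 (1.93 log units; beyond the scatter) even though both groups have 0 hydrogen-bond donors. Against the methanesulfonamido group, the picture is different: a 1.0-fold lower number from compound 1 to compound 3 (0.01 log units; within the scatter) means that these two unlike groups cannot be told apart at this position. Nothing available explains why compound 2 stands apart. Still open, as far as these compounds go, is whether a different group at this position, such as an amine, a carboxylic acid or a plain methyl, would come close to compound 2 or stay near compound 1 and compound 3.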